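From compound 2 to compound 3: an aryl exchange

The compounds below may be only part of what the source reports. "The series", "measured", "known", "first", "only" and "open" are said of these compounds alone.

In a functional assay on HT-29 cells (Homo sapiens) for inhibition, read by sulforhodamine B assay (a lower number here means a stronger inhibitor, a higher number a weaker inhibitor), compound 1 (`COC(=O)CC/C(C)=C/Cc1c(OC)c(C)c2c(c1OCC#CCN1CCN(c3ccc(C#N)cc3)CC1)C(=O)OC2`) gives > 50000 nM as a limit. Compound 2 (`COC(=O)CC/C(C)=C/Cc1c(OC)c(C)c2c(c1OCC#CCN1CCN(c3ccccc3F)CC1)C(=O)OC2`) gives > 50000 nM as a limit too, so it has no exact standing. The measured evidence is the limit of > 50000 nM in this assay, at which 2 of the 2 values shown sit, alone, and it leaves a step that the two limits leave unreadable from compound 1 to compound 2 without a usable size. Compound 3 (`COC(=O)CC/C(C)=C/Cc1c(OC)c(C)c2c(c1OCC#CCN1CCN(c3ccc(O)cc3)CC1)C(=O)OC2`) differs from compound 2 by 4-hydroxyphenyl in place of 2-fluorophenyl on an amine nitrogen in a ring with 4-hydroxyphenyl in place of 2-fluorophenyl on an amine nitrogen in a ring. Going by the values given here, no measured step supports a direction, so the expected change is only a number no higher from compound 2 to compound 3 (the limit leaves the size open) as estimated here. Compound 3 is expected at 50000 nM (estimated range 15000 nM to 80000 nM). Another limit is the likeliest report.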

Compound 3, half-maximal inhibitory concentration: > 50000 nM
Compound 3 was reported as a limit (the forecaster's own chance of this, stated with the estimate: 75%); the middle value lies on the limit itself.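

Compound 3 gives > 50000 nM in this assay, which is a limit. Going by these compounds alone, no step among compound 1, compound 2 and compound 3 can be read. From the compounds shown here alone, whether 4-cyanophenyl, 2-fluorophenyl and 4-hydroxyphenyl differ in effect on inhibition stays open.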